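Phenol-to-fluorine swap on the pendant aryl: oral exposure

This account rests on a few compounds, and the source may have more. Where it says the series, first, only, none or still open, it means among the compounds named here.

Three members of the series share one core. Compound 1 is `CC1=C(c2cccc(O)c2)C(c2ccc(OC[C@@H](C)N3CCCC3)cc2)Oc2ccc(O)cc21`; compound 2 is `CC1=C(c2cccc(O)c2)C(c2ccc(OC[C@H](C)N3CC[C@@H](C)C3)cc2)Oc2ccc(O)cc21`; compound 3, not yet measured, is `CC1=C(c2cccc(F)c2)C(c2ccc(OC[C@H](C)N3CC[C@@H](C)C3)cc2)Oc2ccc(O)cc21`.

In an ADME assay on the whole organism for pharmacokinetics, with Mus musculus as the target, at a dose of 10 mg/kg by the oral route (on this read-out higher numbers stand for higher exposure at the dose given and lower numbers for lower exposure), compound 2 gives 590 ng.h/mL. Among the compounds with values here, this is the only number so far in this assay: compound 1 has no result, its entry standing as "not determined" (no result reported). Within the data shown here, compound 2 therefore sits alone, with nothing measured to rank it against, and no step between measured compounds can be drawn.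

Compound 3 differs from compound 2 in one place: fluoro in place of hydroxy on an aromatic carbon. Nothing in the measured set tracks this change, so the expectation rests on the change alone, not on any shown step.

Expectation: the exposure of compound 3 in this assay is expected to be higher than that of compound 2, by a step of a 2.2-fold higher number from compound 2 to compound 3 (0.34 log units; beyond the scatter), likely beyond the usual scatter but with wide uncertainty. For compound 3 the estimated area under the curve is 1300 ng.h/mL, within a range from 450 ng.h/mL to 3800 ng.h/mL.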

Compound 3, area under the concentration-time curve: 350 ng.h/mL
Compound 3: middle estimate off by 3.7-fold (0.57 log units), on the high side; the whole stated range lies above it.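

In this assay, the swap from 3-hydroxyphenyl to 3-fluorophenyl gives a 1.7-fold lower number from compound 2 to compound 3 (0.23 log units; within the scatter), so at this place, meta to a large group, the two groups cannot be told apart on this read-out. The change takes away the hydrogen-bond donor and acceptor counted for hydroxy, and the two numbers still lie within the scatter of each other, so this one pair gives no sign that oral exposure in the mouse depends on the hydroxy at this place, although a single pair cannot establish a wider pattern across the series. The data shown include no measurement that would explain this result, and the hydroxy on the shared core is the same in both compounds, so the pair says nothing about that group.

As far as these compounds go, whether a methoxy, an amine or a carboxylic acid at this place would also stay within the scatter of compound 2 remains open. Also open, from the compounds shown here alone, is whether the same swap would read alike on the pyrrolidine side chain of compound 1, or with fluoro in place of the hydroxy on the shared core.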